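A carboxy group in place of the tetrazole

The compounds below may be only part of what the source reports. "The series", "measured", "known", "first", "only" and "open" are said of these compounds alone.

Two measured compounds share one core and differ only in a group on a six-membered aromatic ring of carbon only. Compound 1 `CCCS(=O)(=O)Nc1ccc(F)c(C(=O)c2n[nH]c3ncc(-c4ccc(N)cc4)cc23)c1F` carries an amino group there; in an assay for binding affinity to dual specificity mitogen-activated protein kinase kinase 4 (Homo sapiens), read by KINOMEscan, tested at 10 nM (a higher number here means a weaker effect of the compound at the concentration tested, a lower number a stronger effect), compound 1 gives 3.7%. Compound 2 `CCCS(=O)(=O)Nc1ccc(F)c(C(=O)c2n[nH]c3ncc(-c4ccc(-c5nnn[nH]5)cc4)cc23)c1F` carries a 1H-tetrazol-5-yl group on that aromatic carbon; in this assay compound 2 gives 1.1%. The step of a number 2.6 percentage points lower from compound 1 to compound 2 (within the scatter) is within the scatter. Compound 2 thus stands at the lowest of the two numbers shown, with compound 1 as its nearest neighbour and the gap between them within the scatter.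

Compound 3 `CCCS(=O)(=O)Nc1ccc(F)c(C(=O)c2n[nH]c3ncc(-c4ccc(C(=O)O)cc4)cc23)c1F` is not yet measured. It differs from compound 2 in this way: carboxy in place of 1H-tetrazol-5-yl on an aromatic carbon. For the measured compounds named here, the only measured step that bears on this change is a number 2.6 percentage points lower from compound 1 to compound 2 (within the scatter), which exchanged one group on the same aromatic carbon without moving the number beyond the scatter. Going by the values given here, on that basis compound 3 is expected to stay close to compound 2, with no step in this assay beyond the scatter; the expected change is a number 1.9 percentage points higher from compound 2 to compound 3 (within the scatter). The estimate for compound 3 in this assay is 3%, within a range from 0.5% to 12%.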

Compound 3, a percentage reported as activity, at one concentration (the size of the read-out at that concentration, not a potency): 0.2%
The estimate for compound 3 lay 2.8 percentage points above the measured number; measured number below the stated range.
By their numbers in this assay, from the lowest: compounds 3, 2 and 1 (each within the scatter of the next).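

In this assay there is a number 0.9 percentage points lower from compound 2 to compound 3 (within the scatter) for carboxy in place of 1H-tetrazol-5-yl and a number 3.5 percentage points lower from compound 1 to compound 3 (within the scatter) for carboxy in place of amino on the same aromatic carbon. The position para to a large group has now carried three different groups, one of them without a ring and with fewer heavy atoms than 1H-tetrazol-5-yl, and compounds 1, 2 and 3 all stay within the scatter of one another, so this read-out at this single concentration does not separate them. Nothing at hand explains why these exchanges leave the number within the scatter.

On these data alone, it remains open whether a methyl ester, a methoxy group or a longer chain such as an acetic acid side chain at this same place would also stay within the scatter of these three compounds, or whether one of them would give a step beyond it. A read-out at one concentration also leaves open whether amino, 1H-tetrazol-5-yl and carboxy would differ in the strength of their effect at other concentrations.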